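Series notes: oxane ring replaced by a methoxypropyl chain

The source may hold more compounds than are shown below. What is called first, only, known or untested is meant among the compounds shown, and "the series" means these compounds.

Compound 1 `COc1ccccc1-n1nc([C@@H]2CCO[C@H](C(C)C)C2)cc1-c1ccc(Cl)cc1` stands second highest of the three numbers in an ADME assay on microsomes from liver (Homo sapiens) for metabolic stability, with a stated time of 10 min (a lower number here means that less of the compound is left, a higher number that more of the compound is left), where compound 1 gives 66%. Its nearest neighbour is compound 3 `COc1ccccc1-n1nc(C2=CC(C)(C)OC(C)(C)C2)cc1-c1ccc(Cl)cc1`, which in this assay gives 96%; the furthest is compound 2 `COc1ccccc1-n1nc([C@@H]2CCO[C@@H](C(C)C)C2)cc1-c1ccc(Cl)cc1`, which gives 26%. The step of a number 40 percentage points lower from compound 1 to compound 2 (beyond the scatter) goes with the fact that compounds 1 and 2 differ only in the configuration as drawn, and the step of a number 30 percentage points higher from compound 1 to compound 3 (beyond the scatter) exchanges one six-membered ring for another on the same aromatic carbon. The step of a number 70 percentage points higher from compound 2 to compound 3 (beyond the scatter) spans the whole range seen so far.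

Compound 4 `COCCCc1cc(-c2ccc(Cl)cc2)n(-c2ccccc2OC)n1` has not yet been measured. It differs from compound 1 as follows: 3-methoxypropyl in place of 2-isopropyloxan-4-yl on an aromatic carbon. Going by the values given here, none of the measured steps replaces a ring with an open chain at this position, so none bears on the change directly. What the measured steps do show is that changes at this aromatic carbon, whether of configuration or of ring substitution, move this assay by large amounts in either direction. Without a step that matches the change, the expectation for compound 4 is set near the middle of the measured range and is estimated at 45%, between 20% and 75%, which as a step means a number 21 percentage points lower from compound 1 to compound 4 (beyond the scatter) and is expected to be modest in size.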

Compound 4, percent of the compound remaining: 58%
For compound 4 the middle estimate is 13 percentage points below the measured one, and the stated range covers the measured number.
By their numbers in this assay, from the lowest: compound 2; then compounds 4 and 1 (each within the scatter of the next); then compound 3.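

In this assay, the open chain of compound 4 stands level with the oxane ring of compound 1, a number 8 percentage points lower from compound 1 to compound 4 (within the scatter), so a ring at this aromatic carbon is not required for a number in this part of the range. The same exchange, starting from the other oxane configuration, gives a number 32 percentage points higher from compound 2 to compound 4 (beyond the scatter), while the ring of compound 3 remains clearly ahead of the chain, a number 38 percentage points lower from compound 3 to compound 4 (beyond the scatter), so the effect of losing the ring depends on which ring is lost. The low number therefore belongs to compound 2 alone among the compounds with a saturated ring or chain at this position, and what sets it apart from compound 1 is stated in one line: the fact that compounds 1 and 2 differ only in the configuration as drawn.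

The compounds shown do not separate the part played by the chain oxygen from that of chain length, which a plain butyl chain, a longer ether chain or a propyl chain ending in an amine or a carboxylic acid would address. They also leave open which feature of the ring in compound 3 carries its number, since its step from compound 1 changes several ring features at once.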